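A few compounds are considered here, and "the series" means these few. Any claim that something is new, unique, unknown or untested is made for them only; others in the source may bear on it.

Of the compounds shown here, three built on one shared core have been tested in a functional assay on the whole organism (strain CD-1) with Mus musculus as the target, in the maximal electroshock model, with a stated time of 0.5 h; on this read-out lower numbers stand for an effect already at smaller amounts and higher numbers for an effect only at larger amounts of compound. Compound 1 `CC1(c2ccccc2)CC(=O)N(CC(=O)N2CCN(c3ccccc3F)CC2)C1=O` gives 100 mg/kg in this assay. Compound 2 `CC1(c2ccccc2)CC(=O)N(CC(=O)N2CCC(Cc3ccccc3)CC2)C1=O` is recorded in this assay as "not active" (no number reported). Compound 3 `CC1(c2ccccc2)CC(=O)N(CC(=O)N2CCN(c3ccccc3Cl)CC2)C1=O` is recorded in this assay as "not active" (no number reported), so no number stands for it; it is one of two compounds in this set without a number. The step from compound 3 to compound 4 `CC1(c2ccccc2)CC(=O)N(CC(=O)N2CCN(c3cccc(C(F)(F)F)c3)CC2)C1=O` changes one part of the structure: 3-(trifluoromethyl)phenyl in place of 2-chlorophenyl on an amine nitrogen in a ring. Within the data shown here, no measured pair in this set differs by exactly this kind of change, so the size of the step in this assay cannot be read from the data. Only compound 1 gives a number, and the other two do not, so a modest gain, or no change beyond the scatter, seems the most plausible outcome for compound 4, with a real chance that it is also reported without a number. For compound 4, the minimum effective dose in this assay is estimated at 200 mg/kg, with a range from 60 mg/kg to 600 mg/kg.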

Compound 4, minimum effective dose: 300 mg/kg
Compound 4: middle estimate off by 1.5-fold (0.18 log units), on the low side, and the stated range covers the measured number.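

Compound 4 shows that in this assay a number can also be obtained with a group other than 2-fluorophenyl on the amine nitrogen in the ring. Replacing 2-fluorophenyl with 3-(trifluoromethyl)phenyl gives a 3.0-fold higher number from compound 1 to compound 4 (0.48 log units; beyond the scatter) and so shows that the effective dose responds to the group carried at this position, with the new group needing more compound. The step between compound 3 and compound 4 cannot be read as a size, as compound 3 has no number.

Nothing available here accounts for these differences. A 2-(trifluoromethyl)phenyl or 3-fluorophenyl group on the same nitrogen would help to show whether the choice of group or its place on the phenyl ring matters more.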